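This account rests on a few compounds, and the source may have more. Where it says the series, first, only, none or still open, it means among the compounds named here.

In a functional assay on cells (Cancer cell lines, Homo sapiens) for inhibition (on this read-out higher numbers stand for weaker inhibition of growth and lower numbers for stronger inhibition of growth), compound 1 (`Cc1cn2c(/C=N/NC(=N)N)c(-c3ccsc3)nc2s1`) gives 27500 nM and compound 2 (`N=C(N)N/N=C/c1c(-c2cccs2)nc2sccn12`) gives 26900 nM and these two values lie within the scatter of each other, so compound 2 stands level with compound 1. Compound 3 (`Cc1cn2c(/C=N/NC(=N)N)c(-c3cccs3)nc2s1`) is compound 2 with methyl in place of hydrogen on an aromatic carbon. Going by the values given here, no measured pair shows this change on its own, so the only guide is how close those two values are. The estimated step of a 1.0-fold lower number from compound 2 to compound 3 (0.01 log units; within the scatter) is expected to stay within the scatter, with no clear direction. Compound 3 is estimated at 26000 nM with 14000 nM to 50000 nM as its expected range.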

Compound 3, concentration for total growth inhibition: 17400 nM
Beside the measured number, compound 3's estimate is 1.5-fold (0.17 log units) above it, within the range that was stated.
By their numbers in this assay, from the lowest: compounds 3, 2 and 1 (each within the scatter of the next).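

In this assay, putting methyl in place of hydrogen on the aromatic carbon next to the ring sulfur gives a 1.5-fold lower number from compound 2 to compound 3 (0.19 log units; within the scatter) and putting thiophen-2-yl in place of thiophen-3-yl gives a 1.6-fold lower number from compound 1 to compound 3 (0.20 log units; within the scatter), so with the methyl in place, neither this position nor the thiophene attachment shows a clear shift. No supporting data explain these small steps. Still open, on these data alone, is whether another group at this position, such as a longer chain, an amine or a carboxylic acid, would move the number beyond the scatter.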